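Lengthening the Chain on the Core of Compound 2

A few compounds are considered here, and "the series" means these few. Any claim that something is new, unique, unknown or untested is made for them only; others in the source may bear on it.

Compound 1 `CCCCC1(O)C(N)=Nc2ccccc21`: "not active" (no number reported)
Compound 2 `CCCCCn1c(N)nc2ccccc21`: 3230 nM

In an assay on HEK293 cells for agonist activity at Toll-like receptor 8 (Homo sapiens), read by reporter gene assay (on this read-out lower numbers stand for an effect already at smaller amounts and higher numbers for an effect only at larger amounts of compound), compound 1 is reported only as "not active" (no number reported), without a number. Among the measured compounds shown here, compound 2 gives 3230 nM in this assay, the only number available, so it stands alone. Compound 3 `CCCCCCn1c(N)nc2ccccc21` differs from compound 2 by methyl in place of hydrogen on a saturated chain carbon, five bonds along the chain from an aromatic nitrogen. For the measured compounds named here, no step between two measured compounds exists here to guide the size of this change. Compound 3 is expected to come out a little stronger than compound 2, a step of a 2.2-fold lower number from compound 2 to compound 3 (0.33 log units; beyond the scatter) that may still lie within the scatter. The estimate for compound 3 is 1500 nM, ranging from 500 nM to 5000 nM.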

Compound 3, half-maximal effective concentration: 3960 nM
Beside the measured number, compound 3's estimate is 2.6-fold (0.42 log units) below it; the measured number falls inside the stated range.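

In this assay, methyl in place of hydrogen on a saturated chain carbon, five bonds along the chain from an aromatic nitrogen, gives a 1.2-fold higher number from compound 2 to compound 3 (0.09 log units; within the scatter) and so leaves the two compounds indistinguishable. Among the compounds shown here, this is the first numerical reading of a change at this position, and on this single step the added methyl does not separate compound 3 from compound 2. No supporting data bear on this result.

Going by these compounds, whether a longer chain, an amine or a carboxylic acid in place of this methyl would move the number beyond the scatter remains open.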